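Swapping the aryl group on the thiourea of compound 1

The source may report more compounds than this note shows. Statements on the series, on what has been measured and on what is new or still open speak of the compounds shown alone.

Compound 1 `CN(C)c1ccc(NC(=S)N2CCC(C(O)(c3ccccc3)c3ccccc3)CC2)cc1` is a thiourea bearing a 4-(dimethylamino)phenyl group; in a functional assay for antagonist activity at Neuropeptide Y receptor type 2 (Homo sapiens) (a lower number here means a stronger inhibitor, a higher number a weaker inhibitor), compound 1 gives 612 nM. Among the three compounds measured here it stands second highest. Compound 2 `CCN(CC)C(=O)c1ccc(NC(=S)N2CCC(C(O)(c3ccccc3)c3ccccc3)CC2)cc1` gives 78 nM, and compound 3 `CC(C)Oc1ccc(NC(=S)N2CCC(C(O)(c3ccccc3)c3ccccc3)CC2)cc1C#N` gives 899 nM, a number within the usual scatter of that of compound 1.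

Compound 4 `CCOc1ccc(NC(=S)N2CCC(C(O)(c3ccccc3)c3ccccc3)CC2)c(F)c1` differs from compound 1 in one place: 4-ethoxy-2-fluorophenyl in place of 4-(dimethylamino)phenyl on an amide-type nitrogen. Within the data shown here, the only single-point step measured on this position is a 7.8-fold lower number from compound 1 to compound 2 (0.89 log units; beyond the scatter), which replaced the dimethylamino group with a diethylcarbamoyl group rather than with the ethoxy and fluorine substituents entering here. Compound 3, which carries an alkoxy group on the same aromatic ring, sits in the same range as compound 1, so an alkoxy at that position offers no sign of a large shift.

The expected step is therefore small, a 1.1-fold higher number from compound 1 to compound 4 (0.06 log units; within the scatter), with no direction beyond the scatter. Compound 4 is estimated at 700 nM, within the range 250 nM to 2000 nM.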

Compound 4, half-maximal inhibitory concentration: 1350 nM
Estimate against measurement, compound 4: 1.9-fold (0.29 log units) below; measured number inside the range.
By their numbers in this assay, from the lowest: compound 2; then compounds 1, 3 and 4 (each within the scatter of the next, the first and the last beyond it).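

The step of a 2.2-fold higher number from compound 1 to compound 4 (0.34 log units; beyond the scatter) in this assay shows that changing the aryl group on this amide-type nitrogen can also raise the number, whereas the earlier step of a 7.8-fold lower number from compound 1 to compound 2 (0.89 log units; beyond the scatter) showed only a fall. The same position can therefore move the number in either direction, and both steps lie beyond the usual scatter. Because the dimethylamino group leaves and both the ethoxy group and the fluorine enter in one change, this step cannot be assigned to either new substituent alone, and no measurement shown here explains its direction.

A 4-ethoxyphenyl group without the fluorine, or a 2-fluorophenyl group without the ethoxy, would separate the two contributions. From the compounds shown here alone, it also remains open how a carboxylic acid or a smaller dimethylcarbamoyl group would behave at this place on the ring.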